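Shifting the Chlorine on the Chlorophenyl Arm

The source may hold more compounds than are shown below. What is called first, only, known or untested is meant among the compounds shown, and "the series" means these compounds.

Three compounds on a shared core carry a 3-hydroxyphenyl group, a thiophene group and a chlorophenyl group, and differ in where the chlorine sits and how the thiophene is attached. Compound 1 `Oc1cccc(-c2cc(-c3ccc(Cl)cc3)nc(-c3ccsc3)c2)c1` carries 4-chlorophenyl, and in a functional assay on T47D cells (Homo sapiens) for cytotoxicity, read by CCK-8 assay and cell counting, with a stated time of 2 days (on this read-out higher numbers stand for weaker inhibition and lower numbers for stronger inhibition), compound 1 gives 11500 nM. Compound 2 `Oc1cccc(-c2cc(-c3cccc(Cl)c3)nc(-c3cccs3)c2)c1` carries 3-chlorophenyl with a thiophen-2-yl group, and in this assay compound 2 gives 3410 nM. Compound 3 `Oc1cccc(-c2cc(-c3ccsc3)nc(-c3ccccc3Cl)c2)c1` carries 2-chlorophenyl, and in this assay compound 3 gives 2440 nM, which sits at the low end of the three numbers: compound 2 lies within the usual scatter of it, while a 4.7-fold lower number from compound 1 to compound 3 (0.67 log units; beyond the scatter).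

Compound 4 `Oc1cccc(-c2cc(-c3ccsc3)nc(-c3cccc(Cl)c3)c2)c1` has the same atoms joined differently: 3-chlorophenyl in place of 2-chlorophenyl on an aromatic carbon. Among the compounds with values here, only one measured step changes a single place, the one from compound 1 to compound 3, and it is modest; no single step links compound 2 to either compound 3 or compound 4, so its value can only be read as showing that a 3-chlorophenyl arm, in another setting, gives a number a little above compound 3. Compound 4 is therefore expected to show a 1.2-fold higher number from compound 3 to compound 4 (0.09 log units; within the scatter), a shift that should stay within the scatter, and in this assay compound 4 is estimated at 3000 nM, with a range from 1200 nM to 8000 nM.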

Compound 4, half-maximal inhibitory concentration: 3540 nM
The estimate for compound 4 lay 1.2-fold (0.07 log units) below the measured number; measured number inside the range.
By their numbers in this assay, from the lowest: compounds 3, 2 and 4 (each within the scatter of the next); then compound 1.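

In this assay, moving the chlorine from 2-chlorophenyl to 3-chlorophenyl on the aromatic carbon next to the ring nitrogen gives a 1.5-fold higher number from compound 3 to compound 4 (0.16 log units; within the scatter) and so does not separate these two arms. Compound 1 is the one that stands apart among the chlorophenyl isomers: its 4-chlorophenyl arm gives way to 3-chlorophenyl in a 3.2-fold lower number from compound 1 to compound 4 (0.51 log units; beyond the scatter) and to 2-chlorophenyl in a 4.7-fold lower number from compound 1 to compound 3 (0.67 log units; beyond the scatter) so that, on this shared core with a thiophen-3-yl group, only the 4-chloro placement goes with a clearly higher number. Within the data shown here, the new compound also gives the first single-place reading of how the thiophene is attached, since thiophen-3-yl in place of thiophen-2-yl gives a 1.0-fold higher number from compound 2 to compound 4 (0.02 log units; within the scatter) and the two attachments therefore cannot be told apart with a 3-chlorophenyl arm in place.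

From the compounds shown here alone, it remains open whether a methoxy group, an amine or a carboxylic acid in place of the chlorine would move the number in either direction, and whether the 3-hydroxyphenyl group is needed at all. Nothing available here explains why the 4-chlorophenyl arm differs from the other two.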